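From a chloropyridine amide to a phenylethenyl amide

The source may hold more compounds than are shown below. What is called first, only, known or untested is meant among the compounds shown, and "the series" means these compounds.

Measured in a functional assay on SW 1116 cells (Homo sapiens) for antiproliferative activity, read by MTT assay, with a stated time of 48 h; on this read-out higher numbers stand for an effect only at larger amounts of compound and lower numbers for an effect already at smaller amounts:
Compound 1 `O=C(CCc1ccccc1)Nc1nnc(-c2ccc3c(c2)OCCO3)s1`: 16.2 ug/mL
Compound 2 `O=C(Nc1nnc(-c2ccc3c(c2)OCCO3)s1)c1ccc(Cl)nc1`: 30.4 ug/mL

Going by the values given here, compound 2 has the higher of the two numbers, but its only neighbour, compound 1, sits within the scatter of it (a 1.9-fold higher number from compound 1 to compound 2 (0.27 log units; within the scatter)), so the two are not separated. Compound 3 `O=C(/C=C/c1ccccc1)Nc1nnc(-c2ccc3c(c2)OCCO3)s1` differs from compound 2 in one place: 2-phenylethenyl in place of 6-chloropyridin-3-yl on a carbonyl carbon. Among the compounds with values here, only one measured step bears on this position, a 1.9-fold higher number from compound 1 to compound 2 (0.27 log units; within the scatter), and it was within the scatter; it concerns an exchange between phenethyl and 6-chloropyridin-3-yl, not the 2-phenylethenyl group now entering. Compound 1 carries the group most like the entering one, and the values of compound 1 and compound 2 lie close together. Compound 3 is therefore expected to land near both, with the step of a 1.7-fold lower number from compound 2 to compound 3 (0.23 log units; within the scatter) estimated to stay within the scatter. For compound 3 the estimate in this assay is 18 ug/mL, with a range from 6 ug/mL to 55 ug/mL.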

Compound 3, half-maximal effective concentration: 60.2 ug/mL
Compound 3: the middle estimate sits 3.3-fold (0.52 log units) below what was measured; measured number above the stated range.
By their numbers in this assay, from the lowest: compounds 1, 2 and 3 (each within the scatter of the next, the first and the last beyond it).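

In this assay, going by these compounds alone, the change from phenethyl to 2-phenylethenyl on the carbonyl carbon gives a 3.7-fold higher number from compound 1 to compound 3 (0.57 log units; beyond the scatter) and is the first step at this position that clears the scatter, if only modestly. The exchange of 6-chloropyridin-3-yl for 2-phenylethenyl gives a 2.0-fold higher number from compound 2 to compound 3 (0.30 log units; within the scatter) and so leaves compound 2 unseparated from compound 3, which means the position distinguishes two groups that both carry a six-membered aromatic ring of carbon only and differ in a double bond outside aromatic rings. Nothing available explains this difference.

The compounds shown leave open how a phenyl ring directly on the carbonyl carbon, or a longer chain ending in phenyl, would compare with phenethyl. They also leave open whether an amine or a carboxylic acid at the end of such a chain would be tolerated at this position.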